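A few compounds are considered here, and "the series" means these few. Any claim that something is new, unique, unknown or untested is made for them only; others in the source may bear on it.

Measured compounds in an assay on isolated protein for inhibition of DNA topoisomerase 1 (Homo sapiens), with a stated time of 30 min, tested at 100 uM; a higher number here means a stronger effect of the compound at the concentration tested, a lower number a weaker effect:
- compound 1 `Oc1cccc(-c2cc(-c3ccccc3)cc(-c3ccsc3)n2)c1` gives 75.8%
- compound 2 `Oc1cccc(-c2cc(-c3ccccc3)cc(-c3ccncc3)n2)c1` gives 70.4%
- compound 3 `Oc1ccc(-c2cc(-c3ccccc3)cc(-c3ccsc3)n2)cc1` gives 20.4%

Compound 3 stands lowest of the three numbers in this assay; its gap to compound 2 and to compound 1 is beyond the scatter in each case. The step to compound 4 `Oc1ccc(-c2cc(-c3ccccc3)cc(-c3ccc(O)cc3)n2)cc1` is 4-hydroxyphenyl in place of thiophen-3-yl on an aromatic carbon.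

Going by the values given here, two measured steps bear on this. The step of a number 55.4 percentage points lower from compound 1 to compound 3 (beyond the scatter) shows that the 4-hydroxyphenyl arrangement present in compound 3 carries a large loss, and that arrangement is kept in compound 4. The step of a number 5.4 percentage points lower from compound 1 to compound 2 (within the scatter) shows that exchanging the thiophen-3-yl group next to the ring nitrogen for another aromatic ring left the number essentially unchanged. Among the compounds with values here, no measured pair shows a 4-hydroxyphenyl entering at that position, so the direction there is open. On this basis the expected step of a number 4.6 percentage points higher from compound 3 to compound 4 (within the scatter) is small and not clearly beyond the scatter. Compound 4 is therefore estimated at 25%, within a range of 5% to 50%.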

Compound 4, a percentage reported as inhibition, at one concentration (the size of the read-out at that concentration, not a potency): 0.3%
Compound 4: the middle estimate sits 24.7 percentage points above what was measured; measured number below the stated range.
By their numbers in this assay, from the lowest: compound 4; then compound 3; then compounds 2 and 1 (each within the scatter of the next).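

In this assay, the position next to the ring nitrogen turns out not to be indifferent to every aromatic group: the step of a number 20.1 percentage points lower from compound 3 to compound 4 (beyond the scatter) replaces thiophen-3-yl with 4-hydroxyphenyl and lowers an already low number further. The earlier exchange of thiophen-3-yl for pyridin-4-yl, a number 5.4 percentage points lower from compound 1 to compound 2 (within the scatter), stayed within the scatter, but it was read with a 3-hydroxyphenyl group elsewhere on the core, so the two steps do not share a background. No measurement to hand accounts for the new step.

The compounds shown leave open whether the loss follows the hydroxyl of the entering group or its six-membered carbon ring, and whether a 4-aminophenyl group here would give a different number. Also open, from the compounds shown here alone, is how 4-hydroxyphenyl at this position reads on the core of compound 1.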